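Swapping the aromatic five-membered ring for a non-aromatic one

The compounds below may be only part of what the source reports. "The series", "measured", "known", "first", "only" and "open" are said of these compounds alone.

Measured so far:
compound 1 `CC1=CC(=O)N(Nc2nc(-c3cccs3)ncc2C#N)C1=O`: 5000 nM
compound 2 `CC1=CC(=O)N(Nc2nc(-c3cccs3)ncc2-c2nnc(C)o2)C1=O`: 300 nM

Of the compounds shown here, two share the same core and have been tested in a functional assay on Jurkat cells for inhibition of nuclear factor NF-kappa-B complex (Homo sapiens); on this read-out higher numbers stand for weaker inhibition and lower numbers for stronger inhibition. Compound 1 `CC1=CC(=O)N(Nc2nc(-c3cccs3)ncc2C#N)C1=O` gives 5000 nM, while compound 2 `CC1=CC(=O)N(Nc2nc(-c3cccs3)ncc2-c2nnc(C)o2)C1=O` gives 300 nM. Within the data shown here, compound 2 stands at the lowest number of the two; the only comparison available is a 17-fold lower number from compound 1 to compound 2 (1.22 log units; beyond the scatter), a large step.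

Compound 3 `CC1=CC(=O)N(Nc2nc(-c3cccs3)ncc2C2=NCCO2)C1=O` has not yet been measured. It differs from compound 2 in one place: a group of 5 heavy atoms (3 carbon, 1 nitrogen, 1 oxygen; one five-membered non-aromatic ring with 2 hetero atoms) in place of a group of 6 heavy atoms (3 carbon, 2 nitrogen, 1 oxygen; one five-membered aromatic ring with 3 hetero atoms), on an aromatic carbon. Among the measured compounds shown here, the one measured step shows that the group at this position matters strongly, since replacing cyano with the aromatic five-membered ring moved the number a long way. Compound 3 keeps a five-membered ring at the same place but a non-aromatic one with one fewer hetero atom and one fewer hydrogen-bond acceptor, so it is expected to lie between compound 1 and compound 2, closer to compound 2. The expected step is a 2.7-fold higher number from compound 2 to compound 3 (0.43 log units; beyond the scatter). Compound 3 is therefore estimated at 800 nM, with a range from 250 nM to 3000 nM.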

Compound 3, half-maximal inhibitory concentration: 200 nM
Compound 3: the middle estimate sits 4.0-fold (0.60 log units) above what was measured; measured number outside the range, below it.
By their numbers in this assay, from the lowest: compounds 3 and 2 (each within the scatter of the next); then compound 1.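

In this assay the exchange of the aromatic ring for the non-aromatic one gives a 1.5-fold lower number from compound 2 to compound 3 (0.18 log units; within the scatter) and so lies within the scatter: at this aromatic carbon the two rings cannot be told apart, and the 5-methyl-1,3,4-oxadiazol-2-yl group with its aromatic ring is not needed to keep the number low. The non-aromatic ring also gives a 25-fold lower number from compound 1 to compound 3 (1.40 log units; beyond the scatter) against the cyano group, so the large drop first seen with one five-membered ring now appears with a second ring that has a different count of hetero atoms. No independent data bear on why these two rings stand so far from the cyano group.

The compounds shown leave open whether a five-membered ring is required at all or whether an open-chain group, such as a methyl ester or a primary amide, would give a number close to those of compound 2 and compound 3. They also leave open how far the ring can be changed here, for instance to a phenyl ring or to a fully saturated ring such as pyrrolidine.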